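Side-chain step from compound 3 to compound 4

This account rests on a few compounds, and the source may have more. Where it says the series, first, only, none or still open, it means among the compounds named here.

In a functional assay on A549 cells (Homo sapiens) for cytotoxicity, read by MTT assay, with a stated time of 72 h (on this read-out lower numbers stand for stronger inhibition and higher numbers for weaker inhibition), compound 3 (`COc1ncc(-c2ccc3nc(NC(=O)N(C)C)nn3c2)cc1NS(=O)(=O)c1ccc(F)cc1`) gives 1190 nM and compound 1 (`COc1ncc(-c2ccc3nc(NC(=O)NCC(=O)N4CCCCC4)nn3c2)cc1NS(=O)(=O)c1ccc(F)cc1`) gives 2060 nM. These two values cannot be separated: a 1.7-fold lower number from compound 1 to compound 3 (0.24 log units; within the scatter). Compound 2 (`COc1ncc(-c2ccc3nc(NC(=O)N4CCCC4)nn3c2)cc1NS(=O)(=O)c1ccc(F)cc1`), at 3570 nM, stands apart from compound 3 only modestly: a 3.0-fold lower number from compound 2 to compound 3 (0.48 log units; beyond the scatter). Its gap to compound 1 stays small: a 1.7-fold higher number from compound 1 to compound 2 (0.24 log units; within the scatter).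

Compound 4 (`COc1ncc(-c2ccc3nc(NC(=O)NCCN(C)C)nn3c2)cc1NS(=O)(=O)c1ccc(F)cc1`) carries (2-(dimethylamino)ethyl)amino in place of dimethylamino on a carbonyl carbon. For the measured compounds named here, the closest precedent is compound 1, which also has a longer amino chain at that carbonyl carbon, and its step to compound 3 stays small (a 1.7-fold lower number from compound 1 to compound 3 (0.24 log units; within the scatter)). Going by the values given here, no measured compound carries the new chain itself, so this precedent is only indirect. No shift beyond the scatter is expected, with a slight lean towards a higher number. The expected change is a 1.3-fold higher number from compound 3 to compound 4 (0.10 log units; within the scatter). For compound 4 the estimated value is 1500 nM, with an expected range of 500 nM to 4500 nM.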

Compound 4, half-maximal inhibitory concentration: 800 nM
Compound 4: middle estimate off by 1.9-fold (0.27 log units), on the high side; the range from low to high includes it.
By their numbers in this assay, from the lowest: compounds 4, 3, 1 and 2 (each within the scatter of the next, the first and the last beyond it).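

Notes on the side chain: in this assay, the (2-(dimethylamino)ethyl)amino chain on the carbonyl carbon cannot be separated from dimethylamino (a 1.5-fold lower number from compound 3 to compound 4 (0.17 log units; within the scatter)), so this position accepts the longer amine-bearing chain without a loss beyond the scatter. The same chain separates from both other side chains, modestly, with a 4.5-fold lower number from compound 2 to compound 4 (0.65 log units; beyond the scatter) against pyrrolidin-1-yl and a 2.6-fold lower number from compound 1 to compound 4 (0.41 log units; beyond the scatter) where (dimethylamino)methyl replaces (piperidin-1-yl)carbonyl on the saturated chain carbon, and that second gap shows that the chain end alone can move the value beyond the scatter, which no earlier step at this chain end had shown. Nothing available explains these steps.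

Open, as far as these compounds go, is whether the terminal amine or the chain length drives the gap to compound 1. A longer chain such as (3-(dimethylamino)propyl)amino, or a chain ending in a carboxylic acid, would separate these two.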